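Moving the halogen: from compound 3 to compound 4

The compounds below may be only part of what the source reports. "The series", "measured", "known", "first", "only" and "open" are said of these compounds alone.

In a functional assay (muscle tissue) with Cavia porcellus as the target (a higher number here means that more compound is needed for the effect, a lower number that less compound is needed), compound 3 `COC(=O)C1=C(C)N=C(C)/C(=C(\O)OC)C1c1ccccc1Cl` gives 2.19 nM, the lowest of the three numbers measured. Compound 2 `COC(=O)C1=C(C)N=C(C)/C(=C(/O)OC)C1c1c(F)cccc1Cl` gives 7.59 nM and compound 1 `COC(=O)C1=C(C)N=C(C)/C(=C(\O)OC)C1c1cc([N+](=O)[O-])ccc1O` gives 100 nM in this assay, and both of these steps up from compound 3 lie beyond the scatter. The unmeasured compound 4 `COC(=O)C1=C(C)N=C(C)/C(=C(\O)OC)C1c1ccc(I)cc1` differs from compound 3 in one place: 4-iodophenyl in place of 2-chlorophenyl on a saturated ring carbon. Going by the values given here, no measured pair shows this exact change, so the step can only be estimated. A step toward a higher number is expected for compound 4, of the order of a 14-fold higher number from compound 3 to compound 4 (1.14 log units; beyond the scatter) in this assay. Compound 4 is therefore estimated to give 30 nM in this assay, within a range from 8 nM to 150 nM.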

Compound 4, half-maximal effective concentration: 22900 nM
Beside the measured number, compound 4's estimate is 760-fold (2.88 log units) below it; the measured number lies above the stated range.
By their numbers in this assay, from the lowest: compound 3; then compound 2; then compound 1; then compound 4.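

In this assay, this position proves highly sensitive to the group it carries: 4-iodophenyl in place of 2-chlorophenyl keeps the heavy-atom count yet gives a 10000-fold higher number from compound 3 to compound 4 (4.02 log units; beyond the scatter) as the first single-place step seen here. No measurement shown explains the size of this step.

Both the halogen and its place on the phenyl ring change at once, so the compounds shown cannot separate the two. On these data alone, how a plain phenyl group would compare at this position also remains open.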